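The compounds below may be only part of what the source reports. "The series", "measured", "known", "first", "only" and "open" are said of these compounds alone.

Working notes on the chalcone-type series in a functional assay on NCI-H460 cells (Homo sapiens) for cytotoxicity, read by MTT assay; on this read-out lower numbers stand for stronger inhibition and higher numbers for weaker inhibition.

Going by the values given here, compound 1 `COc1cc(/C=C/C(=O)c2sc(Nc3ccc(Cl)cc3)nc2C)cc(OC)c1OC` is the only member with a measured number: in this assay compound 1 gives 22000 nM, and it therefore stands as the sole reference point among the values shown. Compound 2 `COc1cccc(/C=C/C(=O)c2sc(Nc3ccccc3)nc2C)c1` returns a limit of the assay rather than a number, > 25000 nM, in this assay. Compound 3 `Cc1cccc(Nc2nc(C)c(C(=O)/C=C/c3ccccc3Cl)s2)c1` likewise returns only a limit, > 25000 nM, in this assay. Two of the three values thus sit at the limit of > 25000 nM in this assay, at which 2 of the 3 values shown sit, so the measured range of the series is narrow and sits at the weak end.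

Compound 4 `COc1cc(/C=C/C(=O)c2sc(Nc3cccc(Cl)c3)nc2C)cc(OC)c1OC` is the next member. It differs from compound 1 by 3-chlorophenyl in place of 4-chlorophenyl on a nitrogen on an aromatic ring; the trimethoxy-substituted part and the shared core are unchanged. Among the compounds with values here, no measured pair shows what a shift of the chlorine substituent on this ring does, so no direction can be read from the data. The step from compound 1 to compound 4 is expected to stay within the usual scatter, a 1.1-fold higher number from compound 1 to compound 4 (0.04 log units; within the scatter). Compound 4 is therefore estimated at 24000 nM in this assay, with a range from 9000 nM to 60000 nM, and a considerable chance that the assay reports only a limit.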

Compound 4, half-maximal inhibitory concentration: > 25000 nM
Compound 4: a limit, no number; the forecaster's own chance of this, stated with the estimate: 50%; middle value at least 1.0-fold (0.01 log units) away from the limit.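

Going by these compounds alone, exchanging 4-chlorophenyl for 3-chlorophenyl on the nitrogen gives the first step between two compounds that differ in one place: in this assay it reads as an at least 1.1-fold higher number from compound 1 to compound 4 (0.05 log units; that floor lies within the scatter). Compound 4 returns a limit and not a number, so this step has only a floor, with no upper size. Compound 1 remains the only member with a measured number, and the values now gather at a single limit: the limit of > 25000 nM in this assay, at which 3 of the 4 values shown sit.

From the compounds shown here alone, whether the position of the chlorine on this ring matters at all stays open, as the floor of the step lies within the scatter and the true size of the step cannot be read. Also open, going by these compounds, is what a different group on this ring would do in place of the chlorine, such as an amine or a carboxylic acid.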